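This account rests on a few compounds, and the source may have more. Where it says the series, first, only, none or still open, it means among the compounds named here.

Of the compounds shown here, three built on one core have been measured in a functional assay on PANC-1 cells (Homo sapiens) for inhibition, read by MTT assay, with a stated time of 24 h, tested at 10 uM; on this read-out lower numbers stand for less inhibition and higher numbers for more inhibition at the one concentration tested (going by the name of the read-out). Compound 1, `CC(C)=CCC1Cc2c(OC(=O)Nc3ccc(F)cc3)cc(=O)n(CCCO)c2CC1(C)C`, gives 71.2% in this assay. Compound 2, `CC(C)=CCC1Cc2c(OC(=O)Nc3cccc(F)c3)cc(=O)n(CCCO)c2CC1(C)C`, gives 66.1% in this assay. Compound 3, `CC(C)=CCC/C(C)=C/CC1Cc2c(OC(=O)Nc3ccc(F)cc3)cc(=O)n(CCCO)c2CC1(C)C`, gives 43.9% in this assay, the lowest of the three numbers.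

Two single changes connect these. The change 3-fluorophenyl in place of 4-fluorophenyl on an amide-type nitrogen moved the read-out by a number 5.1 percentage points lower from compound 1 to compound 2 (within the scatter). The change 3-methylbut-2-en-1-yl in place of hydrogen on a saturated chain carbon bound to a double-bonded chain carbon moved the read-out by a number 27.3 percentage points lower from compound 1 to compound 3 (beyond the scatter), so compound 3 stands apart from both compound 1 and compound 2.

Compound 4, `CC(C)=CCC/C(C)=C/CC1Cc2c(OC(=O)Nc3cccc(F)c3)cc(=O)n(CCCO)c2CC1(C)C`, has not yet been measured. It differs from compound 3 by 3-fluorophenyl in place of 4-fluorophenyl on an amide-type nitrogen. Going by the values given here, this is the same change as the one from compound 1 to compound 2, and it sits at the same place on an amide-type nitrogen whose other neighbours are a carbonyl carbon; the two cores on which it is made differ by 3-methylbut-2-en-1-yl in place of hydrogen on a saturated chain carbon bound to a double-bonded chain carbon. Among the compounds with values here, since that earlier step was within the scatter, the expectation for compound 4 is a small step, a number 3.9 percentage points lower from compound 3 to compound 4 (within the scatter), in this assay, resting on the single precedent of compound 1 to compound 2 and on the starting point of compound 3 at 43.9%. On that basis compound 4 is estimated to give about 40% in this assay, with a likely range from 28% to 52%.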

Compound 4, a percentage reported as inhibition, at one concentration (the size of the read-out at that concentration, not a potency): 52.3%
For compound 4 the middle estimate is 12.3 percentage points below the measured one; the measured number lies above the stated range.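

In this assay, 3-fluorophenyl in place of 4-fluorophenyl on an amide-type nitrogen now gives a number 8.4 percentage points higher from compound 3 to compound 4 (within the scatter), and this step and the earlier one on the other core do not differ: the same change on two cores in this assay, a number 5.1 percentage points lower (within the scatter) from compound 1 to compound 2 and a number 8.4 percentage points higher (within the scatter) from compound 3 to compound 4, 13.5 percentage points apart, within the scatter of two such steps. The longer chain, 3-methylbut-2-en-1-yl in place of hydrogen on a saturated chain carbon bound to a double-bonded chain carbon, gives a number 13.8 percentage points lower from compound 2 to compound 4 (beyond the scatter), so the number falls on both cores, and again the two steps do not differ: the same change on two cores in this assay, a number 27.3 percentage points lower (beyond the scatter) from compound 1 to compound 3 and a number 13.8 percentage points lower (beyond the scatter) from compound 2 to compound 4, 13.5 percentage points apart, within the scatter of two such steps. Going by these compounds alone, each change therefore carries between these two cores without a detectable dependence on the other, but this rests on only two pairs read at a single concentration, and it neither fixes the size of either step nor shows that the opposite directions of the two fluorophenyl steps mean anything, nor does it say how either change would behave on a different core.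

The compounds shown leave open how a plain phenyl, a chlorophenyl or a methoxyphenyl on the amide-type nitrogen would read on these two cores. They also leave open what an amine or a carboxylic acid in place of the hydroxy group on the propyl chain would do.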